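Solubility outlook for compound 4 after a larger amide substituent

This account rests on a few compounds, and the source may have more. Where it says the series, first, only, none or still open, it means among the compounds named here.

Compound 3 `CNC(=O)c1cc(C(=O)N[C@H]2C[C@@H]2C)cc2c1OC[C@H]2c1ccccc1` carries a 2-methylcyclopropyl group on an amide-type nitrogen. In a physicochemical assay for solubility (on this read-out higher numbers stand for higher solubility and lower numbers for lower solubility), compound 3 gives >= 76 ug/mL, which is a limit of the assay rather than a number. Compound 1 `CNC(=O)c1cc(C(=O)N[C@H]2[C@@H]3COC[C@@H]32)cc2c1OC[C@H]2c1ccccc1` gives >= 165 ug/mL in this assay, also a limit. Compound 2 `CNC(=O)c1cc(C(=O)NCCC[C@H]2OC[C@H](N)CO2)cc2c1OC[C@H]2c1ccccc1` gives >= 153 ug/mL, again a limit. The steps a step that the two limits leave unreadable from compound 1 to compound 3 and a step that the two limits leave unreadable from compound 2 to compound 3 therefore carry no readable size, and the limit of >= 76 ug/mL in this assay, at which 1 of the 3 values shown sits, marks where compound 3 sits. Compound 4 `CCC(=O)N1C[C@@H]2[C@H](C1)[C@H]2NC(=O)c1cc(C(=O)NC)c2c(c1)[C@H](c1ccccc1)CO2` differs from compound 3 by a group of 10 heavy atoms (8 carbon, 1 nitrogen, 1 oxygen; one three-membered non-aromatic ring of carbon only, one five-membered non-aromatic ring with 1 hetero atom) in place of a group of 4 heavy atoms (4 carbon; one three-membered non-aromatic ring of carbon only), on an amide-type nitrogen. For the measured compounds named here, no measured step bears on this change with a readable size, so no shift beyond the scatter is expected in either direction. Compound 4 is estimated at 140 ug/mL, between 60 ug/mL and 300 ug/mL, which means an expected step that the limit leaves unreadable from compound 3 to compound 4.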

Compound 4, solubility: >= 163 ug/mL
Compound 4: a limit, no number; the forecaster's own chance of this, stated with the estimate: 70%; at least 1.1-fold (0.06 log units) between middle value and limit.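

In this assay, for the compounds shown here, compound 4 gives only a limit, as do compound 1, compound 2 and compound 3, so no step involving compound 4 can be read: the limit of >= 163 ug/mL in this assay, at which 1 of the 4 values shown sits. The compounds shown leave open how the amide-nitrogen substituents compare in actual numbers.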